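The source may report more compounds than this note shows. Statements on the series, on what has been measured and on what is new or still open speak of the compounds shown alone.

Measured compounds:
- compound 1, `CC(C(=O)N1CCN(c2ccccc2F)CC1)N1C(=O)CCC1=O`, giving 0% in a functional assay on the whole organism (strain Swiss) with Mus musculus as the target, in the maximal electroshock model, with a stated time of 0.5 h, at a dose of 100 mg/kg by the intraperitoneal route; on this read-out lower numbers stand for a weaker effect and higher numbers for a stronger effect at the one dose given
- compound 2, `CC(C(=O)N1CCN(c2ccc(F)cc2)CC1)N1C(=O)CCC1=O`, giving 0% in this assay
- compound 3, `CCC(C(=O)N1CCN(c2ccccc2F)CC1)N1C(=O)CCC1=O`, giving 0% in this assay

Compound 3 stands level with compounds 1 and 2 in this assay, all three at the same figure. The step of no change at the digits printed from compound 1 to compound 3 (within the scatter), a methyl in place of hydrogen on a saturated chain carbon, did not move the read-out beyond the scatter, and neither did the step of no change at the digits printed from compound 1 to compound 2 (within the scatter), which exchanged one fluorophenyl for another on the amine nitrogen in the ring.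

Compound 4, `CCC(C(=O)N1CCN(c2cccc(C)c2)CC1)N1C(=O)CCC1=O`, is the next member of the series and differs from compound 3 in one place: 3-methylphenyl in place of 2-fluorophenyl on an amine nitrogen in a ring. The change again falls on the aryl group carried by the amine nitrogen in the ring, the same position touched in the step from compound 1 to compound 2, where a new aryl group left the read-out unchanged. Nothing in the measured set points to a rise from this position, so no step beyond the scatter is expected, no change at the digits printed from compound 3 to compound 4 (within the scatter). Compound 4 is therefore estimated at 0% in this assay, within 0% to 15%.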

Compound 4, a percentage reported as activity, at one dose (the size of the read-out at that dose, not a potency): 0%
The estimate for compound 4 equals the measured number at the digits printed; the measured number falls inside the stated range.
By their numbers in this assay, from the lowest: compounds 1, 2, 3 and 4 (each within the scatter of the next).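

In this assay, among these compounds, the result is no change at the digits printed from compound 3 to compound 4 (within the scatter), the first step at the amine nitrogen in the ring to replace a fluorophenyl with an aryl group of carbon only. The earlier step at this position had only exchanged one fluorophenyl for another, so this change shows that the read-out also holds when fluorine leaves the aryl group and a methyl enters it. No measurement given here speaks to why the read-out stays flat.

As far as these compounds go, with all four compounds level, it remains open whether any group on this nitrogen can raise the read-out at all, such as a chlorophenyl, a methoxyphenyl or a benzyl group. From the compounds shown here alone, it is also open whether a longer chain on the saturated chain carbon would move it.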